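The compounds below may be only part of what the source reports. "The series", "measured", "known", "first", "only" and "open" are said of these compounds alone.

Compound 1 `Cc1ccc(N2CCN(C(=O)c3oc(C)nc3-c3ccccc3)CC2)cc1` is one of three amides on a shared core examined here. In a functional assay on HL-60 cells (Homo sapiens) for inhibition, read by MTT assay, with a stated time of 72 h (a higher number here means a weaker inhibitor, a lower number a stronger inhibitor), compound 1 gives > 1000 nM, which is a limit of the assay and not a number. Compound 2 `CCc1nc(-c2cccc(F)c2)c(C(=O)N2CCN(c3cccc(OC)c3)CC2)o1` gives 201 nM in this assay. Compound 3 `COc1ccc(-c2nc(C)oc2C(=O)N2CCN(c3cccc(Cl)c3)CC2)cc1O` is recorded in this assay as "not active" (no number reported). Compound 1 therefore sits at the limit, as the limit of > 1000 nM in this assay, at which 1 of the 3 values shown sits, shows. Compound 4 `Cc1nc(-c2ccccc2)c(C(=O)N2CCN(c3cccc(C#N)c3)CC2)o1` has not yet been measured; it differs from compound 1 by 3-cyanophenyl in place of 4-methylphenyl on an amine nitrogen in a ring. Among the compounds with values here, no step between measured compounds is available, so the expectation rests on the three values alone. The step of an at least 1.2-fold lower number from compound 1 to compound 4 (0.09 log units; that floor lies within the scatter) is expected to be small, toward stronger inhibition, and may not exceed the scatter. Compound 4 is estimated at 800 nM, within 250 nM to 3000 nM.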

Compound 4, half-maximal inhibitory concentration: 39.6 nM
Compound 4: the middle estimate sits 20-fold (1.31 log units) above what was measured; measured number below the stated range.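

In this assay, the group on the amine nitrogen in a ring proves able to move the read-out on its own: 3-cyanophenyl in place of 4-methylphenyl gives an at least 25-fold lower number from compound 1 to compound 4 (1.40 log units; beyond the scatter). The earlier compounds shown here differ from one another in more than one place, so none of them could isolate this position. The full size of the step stays unknown, because the value of compound 1 is a limit of the assay and not a number: the limit of > 1000 nM in this assay, at which 1 of the 4 values shown sits.

Going by these compounds, it remains open whether the nitrile itself matters. Whether 4-cyanophenyl, or a phenyl bearing a trifluoromethyl or a carboxylic acid, would give a similar step at this position is also unresolved.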